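The source may report more compounds than this note shows. Statements on the series, on what has been measured and on what is new or still open speak of the compounds shown alone.

Measured compounds: compound 1 `Cc1c(OCCCCOc2ccc(F)c(C(=O)O)c2)ccc(C(=O)CC(C)(C)C)c1O`, which in an assay on HEK293 cells for positive allosteric modulation of metabotropic glutamate receptor 3 (Rattus norvegicus), read by thallium flux, with a stated time of 2.5 min (a higher number here means that more compound is needed for the effect, a lower number that less compound is needed), gives 258 nM; compound 2 `COC(=O)c1ccc(OCCCCOc2ccc(C(=O)CC(C)C)c(O)c2C)cc1`, which in this assay gives "not determined" (no result reported).

Compound 2 therefore stands without a single number in this assay, and the step to compound 3 `Cc1c(OCCCCOc2ccc(F)c(C(=O)O)c2)ccc(C(=O)CC(C)C)c1O` cannot be sized or given a direction from compound 2 itself. The change is 3-carboxy-4-fluorophenyl in place of 4-(methoxycarbonyl)phenyl on an oxygen on a saturated carbon. Compound 3 shares the entering 3-carboxy-4-fluorophenyl group with compound 1, which in this assay gives 258 nM. On that footing compound 3 is expected to give about 300 nM in this assay, with an estimated range from 100 nM to 1000 nM.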

Compound 3, half-maximal effective concentration: 920 nM
Beside the measured number, compound 3's estimate is 3.1-fold (0.49 log units) below it; the measured number falls inside the stated range.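

With the 3-carboxy-4-fluorophenyl group held constant, the result shows that the assay responds to a small change elsewhere in the molecule: hydrogen in place of methyl on a saturated chain carbon bound to three saturated chain carbons gives a 3.6-fold higher number from compound 1 to compound 3 (0.55 log units; beyond the scatter) in this assay, so more compound is needed for the effect. The step from compound 2 to compound 3 cannot be read. Nothing measured here accounts for the shift. Still open, on these data alone, are the effect of 3-carboxy-4-fluorophenyl in place of 4-(methoxycarbonyl)phenyl taken alone, and how a longer chain or a cyclopropyl group on that carbon would read.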